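The source may report more compounds than this note shows. Statements on the series, on what has been measured and on what is new or still open speak of the compounds shown alone.

Compound 1 `CC(C)[C@H](C(=O)NC(C)(C)C)c1ccc(Cl)cc1` is read in a functional assay on CHO cells for agonist activity at Free fatty acid receptor 2 (Homo sapiens), read by cAMP accumulation (on this read-out lower numbers stand for smaller maximal responses and higher numbers for larger maximal responses), where compound 1 reaches only a limit, < 30%. Compound 2 `CC(C)[C@H](C(=O)Nc1cnns1)c1ccc(Cl)cc1` gives 48% in this assay. Within the data shown here, the single measured step, a number at least 18 percentage points higher from compound 1 to compound 2 (beyond the scatter), starts from the limit of < 30% in this assay, at which 1 of the 2 values shown sits, so its true size is not fixed. Compound 3 `CC(C)[C@H](C(=O)NC1=NC(=O)CS1)c1ccc(Cl)cc1` differs from compound 1 by a group of 6 heavy atoms (3 carbon, 1 nitrogen, 1 oxygen, 1 sulfur; one five-membered non-aromatic ring with 2 hetero atoms) in place of a group of 4 heavy atoms (4 carbon; no ring), on an amide-type nitrogen. This change likewise places a five-membered ring with two hetero atoms on the amide-type nitrogen, so a rise of comparable size is expected, with the caution that the entering ring is non-aromatic. Compound 3 is expected to give 45% in this assay, within 25% to 65%. The expected step is a number at least 15 percentage points higher from compound 1 to compound 3 (beyond the scatter).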

Compound 3, largest response reached (reported as efficacy), in percent of the reference or control that the assay uses: 96%
Estimate against measurement, compound 3: 51 percentage points below; measured number outside the range, above it.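

On an amide-type nitrogen, the non-aromatic ring of compound 3 in place of the aromatic 1,2,3-thiadiazol-5-yl gives in this assay a number 48 percentage points higher from compound 2 to compound 3 (beyond the scatter) at this position, so a five-membered ring carrying hetero atoms does not alone set the response. Against tert-butyl, the change gives a number at least 66 percentage points higher from compound 1 to compound 3 (beyond the scatter) in the same read-out. That size is only a lower bound, as compound 1 stands at a limit: the limit of < 30% in this assay, at which 1 of the 3 values shown sits.

Which part of the entering ring, its carbonyl or its sulfur, carries the rise remains open. Going by these compounds, how a carboxylic acid or an amine on this ring would read also remains open.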